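Adding a Methyl to a Biphenyl Sulfonamide

The source may report more compounds than this note shows. Statements on the series, on what has been measured and on what is new or still open speak of the compounds shown alone.

Compound 1 `O=S(=O)(Nc1cccc(CO)c1)c1ccc(-c2ccccc2)cc1` is tested in an ADME assay on microsomes from liver (Homo sapiens) for metabolic stability, read by LC-MS, tested at 3 uM (a lower number here means that the compound disappears faster, a higher number that the compound lasts longer), and gives 0.133 h. Among the numbers measured so far, compound 1 stands alongside compound 2 `O=S(=O)(Nc1cc(CO)ccc1O)c1ccc(-c2ccc(Br)cc2)cc1`, which gives 0.0833 h, a gap that lies within the usual scatter of this kind of measurement. Compound 3 `O=S(=O)(Nc1ccc(-c2ccc(Cl)cc2Cl)cc1)c1cccc(CO)c1` is reported only as a limit of the assay, > 3.33 h, as the limit of > 3.33 h in this assay, at which 1 of the 3 values shown sits, shows. Compound 4 `Cc1ccc(-c2ccc(S(=O)(=O)Nc3cccc(CO)c3)cc2)cc1` differs from compound 1 in a single place: methyl in place of hydrogen on an aromatic carbon. Going by the values given here, no step between measured compounds connects this change to this assay, so no shift beyond the scatter is expected for the step of a 1.1-fold lower number from compound 1 to compound 4 (0.04 log units; within the scatter). The estimate for compound 4 is 0.12 h, with a range from 0.05 h to 0.3 h.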

Compound 4, half-life: 0.167 h
Compound 4: middle estimate off by 1.4-fold (0.14 log units), on the low side; low and high end bracket the measured number.
By their numbers in this assay, from the lowest: compounds 2, 1 and 4 (each within the scatter of the next). At a limit, above all of these: compound 3.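

In this assay, going by these compounds alone, methyl in place of hydrogen on an aromatic carbon, para to a large group, gives a 1.3-fold higher number from compound 1 to compound 4 (0.10 log units; within the scatter) and so provides the only direct reading of this position. Going from phenyl to 4-methylphenyl leaves the half-life of the shared core within the scatter, a change that the earlier compounds, which differ in more than one place, could not isolate. Nothing measured here bears on the reason for this result.

Going by these compounds, whether an amine, a carboxylic acid or a longer chain at this same position would move the number beyond the scatter remains open. So does the effect of a methyl on another aromatic carbon of this ring.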